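The source may report more compounds than this note shows. Statements on the series, on what has been measured and on what is new or still open speak of the compounds shown alone.

Measured compounds:
- Compound 1 `CN1C/C(=C\c2cccnc2)C(=O)/C(=C/c2ccccc2F)C1`: 4470 nM
- Compound 2 `CN1C/C(=C\c2ccc(C(F)(F)F)cc2)C(=O)/C(=C/c2cccnc2)C1`: 1660 nM

In a functional assay on QGY-7703 cells (Homo sapiens) for cytotoxicity, read by MTT assay, with a stated time of 24 h (on this read-out lower numbers stand for stronger inhibition and higher numbers for weaker inhibition), compound 1 gives 4470 nM and compound 2 gives 1660 nM. Compound 2 has the lower of the two numbers, and the gap between the two lies beyond the scatter. Compound 3 `CN1C/C(=C\c2ccc(C#N)cc2)C(=O)/C(=C/c2cccnc2)C1` carries cyano in place of trifluoromethyl on an aromatic carbon, para to a large group, relative to compound 2: cyano in place of trifluoromethyl on an aromatic carbon. Within the data shown here, no measured pair shows this change on its own. The expected result in this assay is a 1.2-fold higher number from compound 2 to compound 3 (0.08 log units; within the scatter), a small upward step that stays within the scatter. Compound 3 is estimated at 2000 nM, with an expected range from 800 nM to 5000 nM.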

Compound 3, half-maximal inhibitory concentration: > 20000 nM
Compound 3: only a limit was reported (the forecaster's own chance of this, stated with the estimate: 3%); middle value at least 10-fold (1.00 log units) away from the limit.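

This position proves sensitive to the group it carries: in this assay, cyano in place of trifluoromethyl on an aromatic carbon, para to a large group, gives an at least 12-fold higher number from compound 2 to compound 3 (1.08 log units; beyond the scatter). Set against the other measured compound, 4-cyanophenyl in place of 2-fluorophenyl gives an at least 4.4-fold higher number from compound 1 to compound 3 (0.65 log units; beyond the scatter). Compound 3 has only a limit and not a number, so both steps are minimum sizes: the limit of > 20000 nM in this assay, at which 1 of the 3 values shown sits. From the compounds shown here alone, how a methoxy group, an amine or a carboxylic acid on that aromatic carbon would read remains open. Going by these compounds, whether this sensitivity extends beyond these three compounds also remains open.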